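A few compounds are considered here, and "the series" means these few. Any claim that something is new, unique, unknown or untested is made for them only; others in the source may bear on it.

Compound 2 `Clc1ccc(OC(CCn2ccnc2)c2ccc(Cl)cc2)cc1` is one of two compounds tested in an ADME assay on U-937 cells (Homo sapiens) for cytotoxicity, read by MTT assay, with a stated time of 24 h (on this read-out higher numbers stand for lower toxicity in this test and lower numbers for higher toxicity in this test), where compound 2 gives 327000 nM. Among the compounds with values here, its neighbour, compound 1 `Clc1ccc(C(CCn2ccnc2)Oc2ccc(Cl)cc2Cl)cc1`, gives 172000 nM in this assay, and the single measured step, a 1.9-fold higher number from compound 1 to compound 2 (0.28 log units; within the scatter), shows the two numbers sitting within the scatter of each other, so no real separation between them can be claimed.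

Compound 3 `CC(C)c1ccc(OC(CCn2ccnc2)c2ccc(Cl)cc2)cc1` is the next compound, not yet measured. It differs from compound 2 in one place: isopropyl in place of chloro on an aromatic carbon. Within the data shown here, the only measured step, a 1.9-fold higher number from compound 1 to compound 2 (0.28 log units; within the scatter), concerns the removal of a chloro from an aromatic carbon and stayed within the scatter; no measured step exchanges a chloro for an isopropyl, so the evidence bearing on this change is indirect and thin. On that basis the expectation is a step of a 1.1-fold lower number from compound 2 to compound 3 (0.04 log units; within the scatter), which is to say none beyond the scatter. Compound 3 is therefore estimated at 300000 nM in this assay, with a range from 120000 nM to 750000 nM.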

Compound 3, half-maximal cytotoxic concentration: 208000 nM
Compound 3: the middle estimate sits 1.4-fold (0.16 log units) above what was measured; low and high end bracket the measured number.
By their numbers in this assay, from the lowest: compounds 1, 3 and 2 (each within the scatter of the next).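

Replacing chloro with isopropyl on an aromatic carbon, para to a large group, exchanges one chlorine atom for three carbon atoms, and this gives a 1.6-fold lower number from compound 2 to compound 3 (0.20 log units; within the scatter) in this assay. The earlier step, a 1.9-fold higher number from compound 1 to compound 2 (0.28 log units; within the scatter), showed only hydrogen taking the place of a chloro, whereas this result shows that a carbon group with more heavy atoms can stand at this position without a change that can be separated from the usual variation between repeat measurements. No separate measurement is available here to explain this result or to show what either group does at this position.

Still open is whether a group of a different kind at this position, such as an amine or a carboxylic acid, would move the number beyond the scatter, as only chloro and isopropyl are shown there. With every step so far lying within the scatter, the compounds shown also leave open which part of the shared core, if any, has a real bearing on this read-out.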